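This account rests on a few compounds, and the source may have more. Where it says the series, first, only, none or still open, it means among the compounds named here.

For the measured compounds named here, only one reading anchors this small set, and it comes from a functional assay on MDA-MB-231 cells (Homo sapiens) for antiproliferative activity, read by MTT assay, with a stated time of 96 h; a lower number here means a stronger inhibitor, a higher number a weaker inhibitor. In this assay compound 1 (`CC(C)=CCC/C(C)=C/CC/C(C)=C/CC[C@]1(C)CCc2cc(OC(=O)NCc3ccccc3)cc(C)c2O1`) gives > 10000 nM, which is a limit of the assay and not a number. Compound 2 (`CC(C)=CCC/C(C)=C/CC/C(C)=C/CC[C@]1(C)CCc2cc(OC(=O)NC(=O)Oc3ccccc3)c(C)c(C)c2O1`) offers no figure to set beside it, because the entry for compound 2 reads "not determined" (no result reported). Compound 2 therefore has no place of its own on the scale, and the only mark available is the limit of > 10000 nM in this assay, at which 1 of the 2 values shown sits.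

The structure of compound 3 (`CC(C)=CCC/C(C)=C/CC/C(C)=C/CC[C@]1(C)CCc2cc(OC(=O)NCc3ccccc3)c(C)c(C)c2O1`) follows in one change. That change is benzyl in place of phenoxycarbonyl on an amide-type nitrogen, which in words puts benzyl in place of phenoxycarbonyl on an amide-type nitrogen.

Going by the values given here, with no number for compound 2, no measured step can serve as a guide, so no step beyond the usual scatter is expected in this assay, and weak activity is the expected outcome. This expectation leans on compound 1 alone, whose limit is > 10000 nM. The estimated half-maximal inhibitory concentration of compound 3 is 10000 nM, with an expected range from 3000 nM to 30000 nM.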

Compound 3, half-maximal inhibitory concentration: > 10000 nM
Compound 3: only a limit was reported; the forecaster's own chance of this, stated with the estimate: 55%; the middle value lies on the limit itself.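

No size can be read for the step from compound 1 to compound 3, which adds a methyl in place of hydrogen on an aromatic carbon, because each compound gives only a limit and not a number: the limit of > 10000 nM in this assay, at which 2 of the 3 values shown sit.

As far as these compounds go, how strongly compound 1 and compound 3 act, whether that methyl changes their activity, and where compound 2 stands all remain open.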